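A few compounds are considered here, and "the series" means these few. Any claim that something is new, unique, unknown or untested is made for them only; others in the source may bear on it.

Among the compounds with values here, in a functional assay on MCF7 cells (Homo sapiens) for inhibition, read by MTT assay, with a stated time of 72 h (on this read-out higher numbers stand for weaker inhibition and lower numbers for stronger inhibition), compound 3 `COc1cc(NC(C)CCCNC(=O)Nc2ccc(Cl)cc2)c2ncccc2c1` gives 12000 nM, the second highest of the three numbers so far. Compound 1 `COc1cc(NC(C)CCCNC(=O)Nc2ccc(F)cc2)c2ncccc2c1` stands higher at 26000 nM, and compound 2 `COc1cc(NC(C)CCCNC(=O)NNC(=O)Nc2cccc(C(F)(F)F)c2)c2ncccc2c1` stands far lower at 190 nM. Compound 4 `COc1cc(NC(C)CCCNC(=O)NNC(=O)Nc2ccc(O)cc2)c2ncccc2c1` has not yet been measured. Its difference from compound 3 is ((4-hydroxyphenyl)carbamoyl)amino in place of 4-chlorophenyl on an amide-type nitrogen. Within the data shown here, only one measured step changes a single place, a 2.2-fold lower number from compound 1 to compound 3 (0.34 log units; beyond the scatter), with chloro in place of fluoro on an aromatic carbon. That modest step bears only on the 4-chlorophenyl group that leaves and gives no measure for a change of this size. The closer guide is compound 2 at 190 nM, which shares the carbamoyl amino unit with compound 4 but carries trifluoromethyl rather than hydroxy on its phenyl ring. Among the measured compounds shown here, no measured step isolates that difference between the two rings, so the range stays wide. A large move to a lower number is therefore expected in this assay, and the estimated step is a 24-fold lower number from compound 3 to compound 4 (1.38 log units; beyond the scatter). For compound 4 the estimated value is 500 nM, with an expected range from 100 nM to 3000 nM.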

Compound 4, half-maximal inhibitory concentration: 2600 nM
The estimate for compound 4 lay 5.2-fold (0.72 log units) below the measured number; low and high end bracket the measured number.
By their numbers in this assay, from the lowest: compound 2; then compound 4; then compound 3; then compound 1.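

In this assay, ((4-hydroxyphenyl)carbamoyl)amino in place of 4-chlorophenyl on the amide-type nitrogen gives a 4.6-fold lower number from compound 3 to compound 4 (0.66 log units; beyond the scatter), and the same group in place of 4-fluorophenyl gives a 10-fold lower number from compound 1 to compound 4 (1.00 log units; beyond the scatter), so in both of these comparisons the entering group goes with a lower number, even with a hydroxy-bearing ring. The aryl group at the end of the carbamoyl amino unit also matters, as 4-hydroxyphenyl in place of 3-(trifluoromethyl)phenyl on an amide-type nitrogen gives a 14-fold higher number from compound 2 to compound 4 (1.14 log units; beyond the scatter), a large step that shows the carbamoyl amino unit alone does not set the number. Nothing measured here accounts for any of these steps.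

The two aryl groups on that unit differ in both substituent and printed position, so the compounds shown cannot separate the contribution of hydroxy from that of trifluoromethyl, and the effect of the carbamoyl amino unit cannot be read with the ring held constant. Going by these compounds, how a 4-chlorophenyl or 4-fluorophenyl group would behave on that unit remains open, as does the effect of an amine or a carboxylic acid on its phenyl ring.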